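Isobutylamino analogue of compound 2 in the cytotoxicity assay

A few compounds are considered here, and "the series" means these few. Any claim that something is new, unique, unknown or untested is made for them only; others in the source may bear on it.

Three compounds sharing one core have been examined in an ADME assay on HFF cells (Homo sapiens) for cytotoxicity, with a stated time of 8 days; a lower number here means that less compound is tolerated, a higher number that more compound is tolerated. Compound 1 `CCCSc1nc(N)nc2c1ncn2/C=C1/CC1(CO)CO` carries a propylsulfanyl group on an aromatic carbon of that core, and in this assay compound 1 gives > 300000 nM, which is a limit of the assay and not a number. Compound 2 `Nc1nc(NCc2ccccc2)c2ncn(/C=C3/CC3(CO)CO)c2n1` has benzylamino in place of propylsulfanyl on that aromatic carbon, and in this assay compound 2 gives > 300000 nM, again a limit. Compound 3 `Nc1nc2c(ncn2/C=C2/CC2(CO)CO)c(=O)[nH]1` in this assay gives > 300000 nM, also a limit. The step that the two limits leave unreadable from compound 1 to compound 2 is therefore left unreadable by the limit of > 300000 nM in this assay, at which 3 of the 3 values shown sit. Compound 2 thus stands at the limit of the assay, together with the two other compounds, and no number separates any of them.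

Compound 4 `CC(C)CNc1nc(N)nc2c1ncn2/C=C1/CC1(CO)CO` differs from compound 2 by isopropyl in place of phenyl on a saturated chain carbon bound to a nitrogen on an aromatic ring. Within the data shown here, no measured step bears on this change, because every value shown sits at the limit of > 300000 nM in this assay, at which 3 of the 3 values shown sit, so no direction or size of effect can be drawn from the data. Compound 4 is expected to remain at that same limit, so the step of a number no higher from compound 2 to compound 4 (the limit leaves the size open) is expected to show no change beyond the scatter. Compound 4 is accordingly estimated at 300000 nM, within the range 100000 nM to 1000000 nM.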

Compound 4, half-maximal cytotoxic concentration: > 300000 nM
Compound 4: a limit, no number; the forecaster's own chance of this, stated with the estimate: 85%; the middle value lies on the limit itself.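

In this assay compound 4 gives > 300000 nM as a limit of the assay and not a number. Its steps to compound 1 and compound 2 therefore cannot be read: the limit of > 300000 nM in this assay, at which 4 of the 4 values shown sit. The compounds shown leave open at what concentration any of them would become cytotoxic, and whether the groups exchanged on the shared core change that concentration at all.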